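Swapping a Lactam for a Dimethylimidazole on a Shared Core

The source may hold more compounds than are shown below. What is called first, only, known or untested is meant among the compounds shown, and "the series" means these compounds.

Measured so far:
- compound 1, `O=C1CCCN1c1cnc(NCc2c(F)ccc3c2CCO3)c2cn[nH]c(=O)c12`, 1.8
- compound 2, `CN(c1ccn(C)n1)c1cnc(NCc2c(F)ccc3c2CCO3)n2cnnc12`, 1.8
- compound 3, `CN(C)Cc1ccc2c(c1)CN(c1cnc(NCc3c(F)ccc4c3CCO4)n3cnnc13)C2=O`, 1.6

The three compounds were tested in a physicochemical assay for lipophilicity, using the shake flask method, in phosphate buffer, measured as octanol-water partition, with a stated time of 30 min, at pH 7.4; a higher number here means a more lipophilic compound, a lower number a more polar compound. In this assay compound 1 gives 1.8, and compound 2 gives the same reading at the digits shown. Compound 3 reads slightly lower, but that gap lies within the usual scatter, so all three compounds stand at about the same place on this scale, and none can be called more or less lipophilic than another on these numbers alone.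

Compound 4 `Cc1ncc(-c2cnc(NCc3c(F)ccc4c3CCO4)c3cn[nH]c(=O)c23)n1C` has not yet been measured. It differs from compound 1 in one spot: 1,2-dimethyl-1H-imidazol-5-yl in place of 2-oxopyrrolidin-1-yl on an aromatic carbon. Going by the values given here, no pair of measured compounds shows a single change of this kind, so there is no measured step to lean on. Given that the three known values sit so close together, the change is expected to move the reading only modestly, and a number 0.20 log units lower from compound 1 to compound 4 (within the scatter) is the step estimated here, toward a slightly lower number. Compound 4 is therefore expected to give 1.6 in this assay, with a likely range from 1 to 2.2.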

Compound 4, distribution coefficient: 1.9
Beside the measured number, compound 4's estimate is 0.30 log units below it; measured number inside the range.
By their numbers in this assay, from the lowest: compounds 3, 1, 2 and 4 (each within the scatter of the next).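

Replacing 2-oxopyrrolidin-1-yl with 1,2-dimethyl-1H-imidazol-5-yl on this aromatic carbon of the shared core gives a number 0.10 log units higher from compound 1 to compound 4 (within the scatter) in this assay. Going by these compounds alone, this is the first single-place comparison in the set, and it shows that a five-membered non-aromatic ring and a five-membered aromatic ring with 2 hetero atoms can occupy this position without a reading that stands beyond the scatter. Nothing available here explains this result.

From the compounds shown here alone, it remains open whether a carboxylic acid or a morpholine at this position would also leave the reading within the scatter of compound 1. Going by these compounds, it is also open whether the same swap would give a similar step on the different core shared by compound 2 and compound 3.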